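A few compounds are considered here, and "the series" means these few. Any claim that something is new, unique, unknown or untested is made for them only; others in the source may bear on it.

Measured in a functional assay on NALM-6 cells (Homo sapiens) for cytotoxicity, with a stated time of 72 h; on this read-out higher numbers stand for an effect only at larger amounts of compound and lower numbers for an effect already at smaller amounts:
- compound 1 `C=C[C@@](C)(/C=C/c1ccc(O)cc1)CCC=O`: > 43400 nM (a limit)
- compound 2 `C=C[C@@](C)(/C=C/c1ccc(O)cc1)CC/C=C/C(=O)OCC`: > 43400 nM (a limit)
- compound 3 `C=C[C@@](C)(/C=C/c1ccc(O)cc1)CC/C=C(\C)C=O`: 12600 nM

Compound 3 is the only one of the three with an actual number, 12600 nM. The values of compound 1 and compound 2 are both limits.

Next is compound 4 `C=C[C@@](C)(/C=C/c1ccc(O)cc1)CC/C=C(\C)CO`, which has hydroxymethyl in place of formyl on a double-bonded chain carbon bound to a double-bonded chain carbon and a saturated chain carbon.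

Going by the values given here, no measured step makes this exact exchange. The nearest evidence is an at least 3.4-fold lower number from compound 1 to compound 3 (0.53 log units; beyond the scatter) and an at least 3.4-fold lower number from compound 2 to compound 3 (0.53 log units; beyond the scatter). Both show that the 2-formylprop-1-en-1-yl group of compound 3 goes with the lower number, and both sizes are bounded by a limit. Compound 1 also carries a formyl, so formyl alone does not give a readable number in this small set. Removing the formyl from compound 3 is therefore expected to move the number upwards, by about as much as those two steps or somewhat less, and possibly back to the limit. The expected change is a 2.5-fold higher number from compound 3 to compound 4 (0.40 log units; beyond the scatter).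

For compound 4 the estimated value is 32000 nM, with an expected range of 14000 nM to 70000 nM.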

Compound 4, half-maximal effective concentration: > 43400 nM
Compound 4: only a limit was reported (the forecaster's own chance of this, stated with the estimate: 50%); at least 1.3-fold (0.13 log units) between middle value and limit.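

In this assay, going by these compounds alone, hydroxymethyl in place of formyl on a double-bonded chain carbon bound to a double-bonded chain carbon and a saturated chain carbon gives an at least 3.4-fold higher number from compound 3 to compound 4 (0.53 log units; beyond the scatter); this is the first step that changes this one position alone, with the heavy-atom count unchanged and one hydrogen-bond donor added. The carbon skeleton of the side chain therefore does not carry the readable value on its own, since the 2-(hydroxymethyl)prop-1-en-1-yl group keeps it, and the measurable effect in this set goes with the formyl of the 2-formylprop-1-en-1-yl group, although compound 1 goes against any reading of formyl alone as sufficient. The steps linking compound 4 to compound 1 and compound 2 cannot be read, and the full size of the step at this position stays bounded: the limit of > 43400 nM in this assay, at which 3 of the 4 values shown sit.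

From the compounds shown here alone, how a carboxylic acid or an amine on the same double-bonded chain carbon would read remains open. Also open, going by these compounds, is whether the 2-formylprop-1-en-1-yl group keeps its value on a longer chain.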